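Swapping iodo for chloro on the thiophene of compound 1

This account rests on a few compounds, and the source may have more. Where it says the series, first, only, none or still open, it means among the compounds named here.

Measured compounds:
compound 1 `Cc1ccc2nc(Cl)c(/C=C/C(=O)c3ccc(I)s3)cc2c1` gives 129 nM
compound 2 `Cc1ccc2nc(Cl)c(/C=C/C(=O)c3sccc3Br)cc2c1` gives 61.9 nM
compound 3 `Cc1csc(C(=O)/C=C/c2cc3cc(C)ccc3nc2Cl)c1` gives 106 nM

These three compounds were tested in a functional assay on HUVEC cells (Homo sapiens), read by BrdU incorporation, with a stated time of 72 h; on this read-out lower numbers stand for stronger inhibition and higher numbers for weaker inhibition. On that read-out compound 1 has the highest of the three numbers; the nearest is compound 3, a step within the scatter, and the furthest is compound 2, with a 2.1-fold lower number from compound 1 to compound 2 (0.32 log units; beyond the scatter).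

Compound 4 `Cc1ccc2nc(Cl)c(/C=C/C(=O)c3ccc(Cl)s3)cc2c1` has not been measured. It differs from compound 1 in one place: chloro in place of iodo on an aromatic carbon. Among the measured compounds shown here, no measured step makes this exact exchange of one halogen for another at the same place. The two steps that leave from compound 1 replace the iodo group together with its place on the ring: a 2.1-fold lower number from compound 1 to compound 2 (0.32 log units; beyond the scatter) is modest and beyond the scatter, while a 1.2-fold lower number from compound 1 to compound 3 (0.09 log units; within the scatter) stays within it. Neither speaks directly to a chloro group at the same place, so the expected step in this assay is none beyond the scatter, with equal room either way.

Compound 4 is therefore estimated at 130 nM, within a range from 60 nM to 280 nM, meaning an expected 1.0-fold higher number from compound 1 to compound 4 (0.00 log units; within the scatter).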

Compound 4, half-maximal inhibitory concentration: 59.4 nM
Beside the measured number, compound 4's estimate is 2.2-fold (0.34 log units) above it; measured number below the stated range.
By their numbers in this assay, from the lowest: compounds 4, 2, 3 and 1 (each within the scatter of the next, the first and the last beyond it).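

In this assay, among the compounds shown here, chloro in place of iodo, next to the ring sulfur, is the first change that keeps the place fixed and alters only the group, and it gives a 2.2-fold lower number from compound 1 to compound 4 (0.34 log units; beyond the scatter). For the compounds shown here, the choice of halogen at this place therefore moves the number by itself, whereas the earlier steps changed the group and its place on the ring together. The other two steps, a 1.0-fold lower number from compound 2 to compound 4 (0.02 log units; within the scatter) and a 1.8-fold lower number from compound 3 to compound 4 (0.25 log units; within the scatter), stay within the scatter, so compounds 2, 3 and 4 cannot be put in order.

The data shown offer no measured explanation for the gap between the chloro and iodo compounds. As far as these compounds go, it also remains open how an amine, a methoxy group or a carboxylic acid at this same place would compare with chloro.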